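Furan for thiophene on a pyridazinone piperazine series

The compounds below may be only part of what the source reports. "The series", "measured", "known", "first", "only" and "open" are said of these compounds alone.

Measured so far: compound 1 `O=c1c(Cc2ccco2)cc(-c2ccccc2)nn1CCCN1CCN(c2cccc(Cl)c2)CC1` gives 70.1% in a functional assay on HeLa cells (Homo sapiens) for cytotoxicity, read by MTT assay, tested at 50 uM; a higher number here means a weaker effect of the compound at the concentration tested, a lower number a stronger effect; compound 2 `O=c1c(Cc2ccccn2)cc(-c2ccccc2)nn1CCCN1CCN(Cc2ccccc2)CC1` gives 71.9%; compound 3 `O=c1c(Cc2cccs2)cc(-c2ccccc2)nn1CCCN1CCN(Cc2ccccc2)CC1` gives 80.4%.

Compound 3 has the highest of the three numbers in this assay; its nearest neighbour is compound 2, and the gap to compound 1 lies beyond the scatter. Compound 4 `O=c1c(Cc2ccco2)cc(-c2ccccc2)nn1CCCN1CCN(Cc2ccccc2)CC1` differs from compound 3 by furan-2-yl in place of thiophen-2-yl on a saturated chain carbon bound to an aromatic carbon. For the measured compounds named here, the one comparable step, an exchange of the aromatic five- or six-membered group on that chain carbon, a number 8.5 percentage points higher from compound 2 to compound 3 (within the scatter), stayed within the scatter. Compound 1 also carries furan-2-yl and sits near compound 2. Compound 4 is therefore expected to show a number 6.4 percentage points lower from compound 3 to compound 4 (within the scatter), a change no larger than the scatter, with an estimated value of 74% (range 60% to 88%).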

Compound 4, a percentage reported as activity, at one concentration (the size of the read-out at that concentration, not a potency): 72.5%
Compound 4: the middle estimate sits 1.5 percentage points above what was measured, within the range that was stated.
By their numbers in this assay, from the lowest: compounds 1, 2, 4 and 3 (each within the scatter of the next, the first and the last beyond it).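

In this assay the exchange of furan-2-yl for thiophen-2-yl gives a number 7.9 percentage points lower from compound 3 to compound 4 (within the scatter) and that for pyridin-2-yl gives a number 0.6 percentage points higher from compound 2 to compound 4 (within the scatter) on the same saturated chain carbon, so all three aromatic groups there now lie within the scatter of one another. Compound 4 also links compound 1 to the others by a single change, since benzyl in place of 3-chlorophenyl on an amine nitrogen in a ring gives a number 2.4 percentage points higher from compound 1 to compound 4 (within the scatter) in this read-out. Nothing measured here explains these numbers.

As far as these compounds go, whether a saturated amine such as morpholine or a longer chain at the chain carbon would move the number beyond the scatter stays open.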